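A few compounds are considered here, and "the series" means these few. Any claim that something is new, unique, unknown or untested is made for them only; others in the source may bear on it.

Three compounds share one core and differ only in the group on the outer benzene ring. Compound 1 `N#CCCn1nc(-c2ccc(OCc3ccccc3)cc2)oc1=O` carries hydrogen there and in an assay for inhibition of Amine oxidase [flavin-containing] B (Rattus norvegicus) (a higher number here means a weaker inhibitor, a lower number a stronger inhibitor), compound 1 gives 2.2 nM. Compound 2 `COc1ccc(COc2ccc(-c3nn(CCC#N)c(=O)o3)cc2)cc1` carries methoxy and gives 27 nM; compound 3 `Cc1ccc(COc2ccc(-c3nn(CCC#N)c(=O)o3)cc2)cc1` carries methyl and gives 15 nM. Compound 3 thus holds the second highest of the three numbers: one measured step was a 6.8-fold higher number from compound 1 to compound 3 (0.83 log units; beyond the scatter), and the other was a 1.8-fold lower number from compound 2 to compound 3 (0.26 log units; within the scatter), so compound 2 and compound 3 cannot be told apart. Compound 4 `N#CCCn1nc(-c2ccc(OCc3ccc([N+](=O)[O-])cc3)cc2)oc1=O` brings the next change: nitro in place of methyl on an aromatic carbon. For the measured compounds named here, no measured step places nitro on that aromatic carbon, but both groups tried there so far gave a higher number than hydrogen, the bigger of those two steps being a 12-fold higher number from compound 1 to compound 2 (1.09 log units; beyond the scatter). Nitro is expected to fall into the same band as methoxy and methyl, so for compound 4 a step of a 1.7-fold higher number from compound 3 to compound 4 (0.22 log units; within the scatter) is expected, within the scatter. Compound 4 is therefore estimated at 25 nM, with a likely range from 6 nM to 100 nM.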

Compound 4, half-maximal inhibitory concentration: 5500 nM
The estimate for compound 4 lay 220-fold (2.34 log units) below the measured number, and the stated range ends below it.
By their numbers in this assay, from the lowest: compound 1; then compounds 3 and 2 (each within the scatter of the next); then compound 4.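

Until now the position looked fairly forgiving, with methyl and methoxy within the scatter of each other, but nitro shows that the group here can change the result in this assay far more than those two suggested. The change gives a 370-fold higher number from compound 3 to compound 4 (2.56 log units; beyond the scatter) and a 200-fold higher number from compound 2 to compound 4 (2.31 log units; beyond the scatter), both much larger than any earlier step, and measured from hydrogen it reaches a 2500-fold higher number from compound 1 to compound 4 (3.40 log units; beyond the scatter), so hydrogen, methyl and methoxy span a narrow band while nitro stands far outside it. Nothing available here accounts for this jump.

Whether the loss is peculiar to nitro stays open, since only one compound shown carries it. An amine, a carboxylic acid or a chlorine atom in the same place would show whether the number stays near compound 3 or climbs toward compound 4.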